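This account rests on a few compounds, and the source may have more. Where it says the series, first, only, none or still open, it means among the compounds named here.

The three measured compounds, each read in a functional assay on HepG2 cells (Homo sapiens) for cytotoxicity, read by sulforhodamine B assay, with a stated time of 48 h; a higher number here means a weaker inhibitor, a lower number a stronger inhibitor:

Compound 1 `CCOC(=O)c1c(-c2ccccc2)c(C#N)c(=O)n(/N=C(\C)c2ccc(NS(=O)(=O)c3ccc(Cl)cc3)cc2)c1N` gives 16800 nM.
Compound 2 `CCOC(=O)c1c(-c2ccc(C)cc2)c(C#N)c(=O)n(/N=C(\C)c2ccc(NS(=O)(=O)c3ccc(Cl)cc3)cc2)c1N` gives 8380 nM.
Compound 3 `CCOC(=O)c1c(-c2ccccc2Cl)c(C#N)c(=O)n(/N=C(\C)c2ccc(NS(=O)(=O)c3ccc(Cl)cc3)cc2)c1N` gives 11400 nM.

Compound 3 stands second highest of these three numbers. Its nearest neighbour is compound 2, reached by a 1.4-fold higher number from compound 2 to compound 3 (0.13 log units; within the scatter), and its furthest is compound 1, reached by a 1.5-fold lower number from compound 1 to compound 3 (0.17 log units; within the scatter). The three values thus sit within the scatter of one another, and no order can be read among them.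

Compound 4 `CCOC(=O)c1c(-c2ccc([N+](=O)[O-])cc2)c(C#N)c(=O)n(/N=C(\C)c2ccc(NS(=O)(=O)c3ccc(Cl)cc3)cc2)c1N` differs from compound 3 in one place: 4-nitrophenyl in place of 2-chlorophenyl on an aromatic carbon. The position is an aromatic carbon of the shared core, opposite the ring nitrogen and para to a large group.

All three measured steps bear on this same position. From compound 1 to compound 3, a 1.5-fold lower number from compound 1 to compound 3 (0.17 log units; within the scatter); from compound 2 to compound 3, a 1.4-fold higher number from compound 2 to compound 3 (0.13 log units; within the scatter); and from compound 1 to compound 2, a 2.0-fold lower number from compound 1 to compound 2 (0.30 log units; within the scatter). None of these changes on the pendant phenyl ring moved the number beyond the scatter. Among the measured compounds shown here, no measured compound carries a nitro group, so the group that enters has no direct precedent among them. The expected step is a 1.0-fold lower number from compound 3 to compound 4 (0.02 log units; within the scatter), that is, no change beyond the scatter. Compound 4 is estimated at 11000 nM, with a range from 4500 nM to 28000 nM.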

Compound 4, half-maximal inhibitory concentration: 41100 nM
Compound 4: middle estimate off by 3.7-fold (0.57 log units), on the low side; the whole stated range lies below it.
By their numbers in this assay, from the lowest: compounds 2, 3 and 1 (each within the scatter of the next); then compound 4.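

Among the compounds shown here, at this position, opposite the ring nitrogen, changes on the pendant phenyl ring had so far stayed within the scatter in this assay. For the compounds shown here, the 4-nitrophenyl group gives the first change that does not, with a 3.6-fold higher number from compound 3 to compound 4 (0.56 log units; beyond the scatter) and a 4.9-fold higher number from compound 2 to compound 4 (0.69 log units; beyond the scatter) and also a 2.4-fold higher number from compound 1 to compound 4 (0.39 log units; beyond the scatter), all three in the direction of a weaker inhibitor. The position therefore does respond to what the pendant ring carries, although nothing among the compounds shown accounts for this shift.

The nitro group is the only group here that moves the number beyond the scatter, so the compounds shown leave open whether an amine, a methoxy group or a carboxylic acid in its place on the phenyl ring would move the number the same way. As far as these compounds go, the step was also read only on the shared core with its ethoxycarbonyl group and nitrile in place, and whether it would hold with a carboxylic acid or an amide in place of that ethoxycarbonyl group remains open.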